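The source may hold more compounds than are shown below. What is called first, only, known or untested is meant among the compounds shown, and "the series" means these compounds.

Of the compounds shown here, three built on one shared core have been measured in a functional assay on A549 cells (Homo sapiens) for antiproliferative activity, read by MTT assay, with a stated time of 24 h; a lower number here means a stronger inhibitor, a higher number a weaker inhibitor. Compound 1 `COc1cc(C(=O)/C=C/c2cc(-c3cc(OC)c(OC)c(OC)c3)n3nc(-c4ccccc4)cc3n2)cc(OC)c1OC` gives 20500 nM. Compound 2 `COc1ccc(-c2cc(/C=C/C(=O)c3cc(OC)c(OC)c(OC)c3)nc3cc(-c4ccccc4)nn23)cc1OC` gives 7200 nM. Compound 3 `COc1ccc(/C=C/C(=O)c2cc(-c3ccc(OC)c(OC)c3)n3nc(-c4ccccc4)cc3n2)cc1` gives 19300 nM. Among these three numbers compound 3 stands second highest: its value and that of compound 1 lie within the scatter of each other, while compound 2 sits beyond the scatter with the lower number of the set. Compound 4 `COc1ccc(-c2cc(C(=O)/C=C/c3ccc(Cl)cc3)nc3cc(-c4ccccc4)nn23)cc1OC` has not yet been measured. It differs from compound 3 in one place: chloro in place of methoxy on an aromatic carbon, at a position para to a large group. Among the measured compounds shown here, only one measured step is available for comparison, a 2.8-fold lower number from compound 1 to compound 2 (0.45 log units; beyond the scatter), and that step replaces methoxy with hydrogen rather than with chloro, so it bears on the present change only loosely. For the measured compounds named here, the measured numbers span a narrow range and no step within it exceeds modest size, so the expected step of a 1.3-fold lower number from compound 3 to compound 4 (0.11 log units; within the scatter) is small, with its direction uncertain. Compound 4 is therefore expected to give about 15000 nM, within a range from 5000 nM to 45000 nM.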

Compound 4, half-maximal inhibitory concentration: 22000 nM
Compound 4: the middle estimate sits 1.5-fold (0.17 log units) below what was measured, and the stated range covers the measured number.
By their numbers in this assay, from the lowest: compound 2; then compounds 3, 1 and 4 (each within the scatter of the next).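

Putting chloro in place of methoxy on this aromatic carbon, para to a large group, gives a 1.1-fold higher number from compound 3 to compound 4 (0.06 log units; within the scatter) in this assay. Among the compounds shown here, the exchange removes a hydrogen-bond acceptor and a heavy atom at this place, yet the two numbers cannot be told apart, so this is the first sign that the position accepts such a swap without a readable difference in this assay. Nothing on hand gives a measured reason for this outcome.

The compounds shown leave open whether a group of another kind at this place, such as an amine or a carboxylic acid, would move the number beyond the scatter. They also leave open whether chloro in place of methoxy would read the same on other aromatic carbons of the shared core.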